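Swapping Anilino for Pyridylmethylamino: Expected Cytotoxicity

The compounds below may be only part of what the source reports. "The series", "measured", "known", "first", "only" and "open" are said of these compounds alone.

Compound 1 `CNc1nc(C)c(-c2nc3ccccc3s2)c(N[C@@H]2C[C@H](CO)[C@@H](O)[C@H]2O)n1` gives > 25000 nM in an ADME assay on cells (Homo sapiens) for cytotoxicity, read by polymerase chain reaction, with a stated time of 3 days (a lower number here means that less compound is tolerated, a higher number that more compound is tolerated), which is a limit of the assay rather than a number.
Compound 2 `CCNc1nc(C)c(-c2nc3ccccc3s2)c(N[C@@H]2C[C@H](CO)[C@@H](O)[C@H]2O)n1` gives 12000 nM in this assay.
Compound 3 `Cc1nc(Nc2ccccc2)nc(N[C@@H]2C[C@H](CO)[C@@H](O)[C@H]2O)c1-c1nc2ccccc2s1` gives > 25000 nM in this assay, again a limit of the assay.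

Compound 3 therefore stands at the top of what was measured, at the limit of > 25000 nM in this assay, at which 2 of the 3 values shown sit. Compound 4 `Cc1nc(NCc2ccncc2)nc(N[C@@H]2C[C@H](CO)[C@@H](O)[C@H]2O)c1-c1nc2ccccc2s1` differs from it in one place: (pyridin-4-yl)methyl in place of phenyl on a nitrogen on an aromatic ring. Going by the values given here, no measured step covers this exact change. The nearest are an at least 2.0-fold higher number from compound 2 to compound 3 (0.31 log units; beyond the scatter) and a step that the two limits leave unreadable from compound 1 to compound 3, so only the direction toward more tolerated compound is hinted at, not the size. Compound 4 is expected to give 25000 nM, between 10000 nM and 60000 nM. The expected step of a number no higher from compound 3 to compound 4 (the limit leaves the size open) is thus judged as none beyond the scatter, and the result is expected to be, once more, only a limit.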

Compound 4, half-maximal cytotoxic concentration: 7000 nM
Compound 4: middle estimate off by 3.6-fold (0.55 log units), on the high side; measured number outside the range, below it.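

In this assay, the group on this nitrogen clearly matters: (pyridin-4-yl)methyl in place of phenyl gives an at least 3.5-fold lower number from compound 3 to compound 4 (0.55 log units; beyond the scatter), and in place of the small methyl it gives an at least 3.5-fold lower number from compound 1 to compound 4 (0.55 log units; beyond the scatter). Against the ethyl group, the change gives a 1.7-fold lower number from compound 2 to compound 4 (0.23 log units; within the scatter), so these two compounds cannot be told apart. Only some of the groups at this position reach the assay's upper limit: the limit of > 25000 nM in this assay, at which 2 of the 4 values shown sit.

The compounds shown leave open whether the lower number goes with the added chain carbon or with the ring nitrogen. A benzyl group on this nitrogen would separate the two.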